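A few compounds are considered here, and "the series" means these few. Any claim that something is new, unique, unknown or untested is made for them only; others in the source may bear on it.

Measured so far in an ADME assay on S9 fraction from liver (Rattus norvegicus) for metabolic stability, read by LC-MS, using NADPH, with a stated time of 30 min; a lower number here means that less of the compound is left, a higher number that more of the compound is left:
compound 1 `CCCCCCCCc1ccc(OCC(=O)Cn2nnc(-c3ccc(Cl)cc3)n2)cc1`, 74%
compound 2 `CCCCCCCCc1ccc(OCC(=O)Cn2nnc(-c3cccc(S(=O)(=O)N(C)C)c3)n2)cc1`, 9%
compound 3 `CCCCCCCCc1ccc(OCC(=O)Cn2nnc(-c3cccs3)n2)cc1`, 8%

Compound 1 stands highest of the three numbers in this assay. The drop a number 65 percentage points lower from compound 1 to compound 2 (beyond the scatter) and the drop a number 66 percentage points lower from compound 1 to compound 3 (beyond the scatter) are both large, while a number 1 percentage points lower from compound 2 to compound 3 (within the scatter) lies within the scatter.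

Compound 4 `CCCCCCCCc1ccc(OCC(=O)Cn2nnc(-c3ccc(C(=O)O)cc3)n2)cc1` differs from compound 1 by carboxy in place of chloro on an aromatic carbon. Neither measured step bears directly on this change: each replaces the whole 4-chlorophenyl by a different aryl ring, whereas here the chloro alone gives way to carboxy on the same ring. Both measured departures from compound 1 in this assay were large downward steps, so a downward step beyond the scatter is expected for compound 4 as well, though with wide uncertainty. The expected step is a number 39 percentage points lower from compound 1 to compound 4 (beyond the scatter). Compound 4 is estimated at 35%, in the range 8% to 70%.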

Compound 4, percent of the compound remaining: < 5%
Compound 4 was reported as a limit; the forecaster's own chance of this, stated with the estimate: 2%; at least 30 percentage points between middle value and limit.
By their numbers in this assay, from the lowest: compounds 3 and 2 (each within the scatter of the next); then compound 1. At a limit, below all of these: compound 4.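

In this assay compound 4 is reported only as a limit, < 5%. With the six-membered ring kept, carboxy in place of chloro on an aromatic carbon gives a large step, a number at least 69 percentage points lower from compound 1 to compound 4 (beyond the scatter), so a change of this one group, para to a large group, is enough for a large step downward, without replacing the whole aryl ring. With 4-carboxyphenyl in place of thiophen-2-yl the step is a number at least 3 percentage points lower from compound 3 to compound 4 (that floor lies within the scatter), and with 4-carboxyphenyl in place of 3-(dimethylsulfamoyl)phenyl it is a number at least 4 percentage points lower from compound 2 to compound 4 (that floor lies within the scatter).

From the compounds shown here alone, what a fluoro, a methoxy or a methyl ester on this carbon would give stays open, as does whether any group other than chloro keeps the number near that of compound 1.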